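Replacing methoxy with chloro: what to expect

This account rests on a few compounds, and the source may have more. Where it says the series, first, only, none or still open, it means among the compounds named here.

Compound 1 `Nc1ccccc1NC(=O)c1ccc(NCC(=O)Nc2ccc([N+](=O)[O-])cc2)cc1`: 6500 nM
Compound 2 `Nc1ccccc1NC(=O)c1ccc(NCC(=O)Nc2cccc([N+](=O)[O-])c2)cc1`: 9000 nM
Compound 3 `COc1ccc(NC(=O)CNc2ccc(C(=O)Nc3ccccc3N)cc2)cc1`: 38000 nM

In a functional assay on HCT-116 cells (Homo sapiens) for inhibition, read by MTT assay, with a stated time of 2 days (a lower number here means a stronger inhibitor of growth, a higher number a weaker inhibitor of growth), compound 3 gives the highest of the three numbers, 38000 nM. Compound 4 `Nc1ccccc1NC(=O)c1ccc(NCC(=O)Nc2ccc(Cl)cc2)cc1` carries chloro in place of methoxy on an aromatic carbon, para to a large group (chloro in place of methoxy on an aromatic carbon). Within the data shown here, no chloro compound has been measured, so the closest guides are the steps between nitro and methoxy: a 5.8-fold higher number from compound 1 to compound 3 (0.77 log units; beyond the scatter) and a 4.2-fold higher number from compound 2 to compound 3 (0.63 log units; beyond the scatter). Moving the nitro group made little difference: a 1.4-fold higher number from compound 1 to compound 2 (0.14 log units; within the scatter). Leaving methoxy may therefore give back part of those steps, so a smaller move towards a lower number is expected in this assay. The expected step is a 2.5-fold lower number from compound 3 to compound 4 (0.40 log units; beyond the scatter). For compound 4 the estimate is 15000 nM, with an expected range of 6000 nM to 38000 nM.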

Compound 4, concentration for total growth inhibition: 62500 nM
Compound 4: the middle estimate sits 4.2-fold (0.62 log units) below what was measured; the whole stated range lies below it.
By their numbers in this assay, from the lowest: compounds 1 and 2 (each within the scatter of the next); then compounds 3 and 4 (each within the scatter of the next).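

In this assay the change gives a 1.6-fold higher number from compound 3 to compound 4 (0.22 log units; within the scatter) here, so chloro and methoxy cannot be told apart at this position. Chloro in place of nitro gives a 9.6-fold higher number from compound 1 to compound 4 (0.98 log units; beyond the scatter) and 4-chlorophenyl in place of 3-nitrophenyl gives a 6.9-fold higher number from compound 2 to compound 4 (0.84 log units; beyond the scatter), so among these compounds the lower numbers belong to the two nitro compounds alone. Nothing available explains this result. Still open, going by these compounds, is whether an amine or a carboxylic acid at this position would give numbers like those of the nitro compounds or like those of compound 3 and compound 4.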